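A few compounds are considered here, and "the series" means these few. Any claim that something is new, unique, unknown or untested is made for them only; others in the source may bear on it.

Measured so far in this series:
compound 1 `COc1c(N2C[C@H]3CCCN(C(=O)Cn4cc(CN5C(=O)C(=O)c6ccccc65)nn4)[C@H]3C2)c(F)cc2c(=O)c(C(=O)O)cn(C3CC3)c12` — 32 ug/mL
compound 2 `COc1c(N2C[C@H]3CCCN(C(=O)Cn4cc(CN5C(=O)C(=O)c6cc(F)ccc65)nn4)[C@H]3C2)c(F)cc2c(=O)c(C(=O)O)cn(C3CC3)c12` — 16 ug/mL
compound 3 `CO/N=C1/C(=O)N(Cc2cn(CC(=O)N3CCC[C@@H]4CN(c5c(F)cc6c(=O)c(C(=O)O)cn(C7CC7)c6c5OC)C[C@@H]43)nn2)c2ccccc21` — 128 ug/mL

In an ADME assay on Vero cells (Chlorocebus sabaeus) for cytotoxicity, read by MTT assay, with a stated time of 72 h (a lower number here means that less compound is tolerated, a higher number that more compound is tolerated), compound 1 gives 32 ug/mL, and compound 2 gives 16 ug/mL. The change between them is fluoro in place of hydrogen on an aromatic carbon, and it gave a 2.0-fold lower number from compound 1 to compound 2 (0.30 log units; within the scatter). Compound 3 gives 128 ug/mL in this assay, the highest of the three values, with its gaps to compound 1 and compound 2 both beyond the scatter. The difference between the core of compound 3 and the core of compound 1 is not broken down here.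

Compound 4 `CO/N=C1/C(=O)N(Cc2cn(CC(=O)N3CCC[C@@H]4CN(c5c(F)cc6c(=O)c(C(=O)O)cn(C7CC7)c6c5OC)C[C@@H]43)nn2)c2ccc(F)cc21` differs from compound 3 by fluoro in place of hydrogen on an aromatic carbon, the same change as that from compound 1 to compound 2. The step from compound 3 to compound 4 in this assay is expected to be a 1.6-fold lower number from compound 3 to compound 4 (0.20 log units; within the scatter), resting on a 2.0-fold lower number from compound 1 to compound 2 (0.30 log units; within the scatter). Compound 4 is therefore estimated at 80 ug/mL, between 32 ug/mL and 160 ug/mL.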

Compound 4, half-maximal cytotoxic concentration: 32 ug/mL
Compound 4: middle estimate off by 2.5-fold (0.40 log units), on the high side, and the stated range covers the measured number.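

In this assay fluoro in place of hydrogen on an aromatic carbon gives a 4.0-fold lower number from compound 3 to compound 4 (0.60 log units; beyond the scatter), in the same direction as the step on the core of compound 1. The two steps do not differ beyond the scatter, so across these two cores the change carries over in direction and, within that scatter, in size: the same change on two cores in this assay, a 2.0-fold lower number (0.30 log units; within the scatter) from compound 1 to compound 2 and a 4.0-fold lower number (0.60 log units; beyond the scatter) from compound 3 to compound 4, 2.0-fold (0.30 log units) apart, within the scatter of two such steps. This rests on one pair per core and one place on the ring, so it does not show the size of the step on any other core, nor what lies behind it.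

Open, going by these compounds, is whether chloro, methyl or an amine at the same place would shift the number as fluoro does. Also open, on these data alone, is whether either of these groups would behave alike on both cores.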